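Nitro and Chain Changes on a Shared Aryl Ketone Core

The compounds below may be only part of what the source reports. "The series", "measured", "known", "first", "only" and "open" are said of these compounds alone.

Compound 1: `C=C(C)C(=O)c1ccc(OCc2nc(-c3ccccc3)cs2)cc1Cl` — 100%
Compound 2: `C=C(CC)C(=O)c1ccc(OCc2nc(-c3ccc([N+](=O)[O-])cc3)cs2)cc1Cl` — 10.2%

Of the compounds shown here, two have been measured in an assay on HL-60 cells for inhibition of glutathione S-transferase P (Homo sapiens), read by spectrophotometry, tested at 5 uM; on this read-out lower numbers stand for less inhibition and higher numbers for more inhibition at the one concentration tested (going by the name of the read-out). Compound 1, `C=C(C)C(=O)c1ccc(OCc2nc(-c3ccccc3)cs2)cc1Cl`, gives 100%. Compound 2, `C=C(CC)C(=O)c1ccc(OCc2nc(-c3ccc([N+](=O)[O-])cc3)cs2)cc1Cl`, gives 10.2%, the lowest of the two numbers, and its distance from compound 1 lies beyond the scatter. The two differ in more than one place, so their values are reported side by side without a step between them.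

Compound 3, `C=C(C)C(=O)c1ccc(OCc2nc(-c3ccc([N+](=O)[O-])cc3)cs2)cc1Cl`, has not yet been measured. Its change from compound 2 is hydrogen in place of methyl on a saturated chain carbon bound to a double-bonded chain carbon. Compound 3 carries the same methyl as compound 1 and the same nitrophenyl as compound 2, so the data give no direct guide to the size of the step, and a moderate rise is expected rather than none. The step from compound 2 to compound 3 is expected to be a number 29.8 percentage points higher from compound 2 to compound 3 (beyond the scatter). For compound 3 an inhibition of 40% is estimated, within a range from 8% to 85%.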

Compound 3, a percentage reported as inhibition, at one concentration (the size of the read-out at that concentration, not a potency): 86.7%
For compound 3 the middle estimate is 46.7 percentage points below the measured one, outside the stated range (above it).
By their numbers in this assay, from the lowest: compound 2; then compound 3; then compound 1.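

In this assay, hydrogen in place of methyl on a saturated chain carbon bound to a double-bonded chain carbon gives a large step, a number 76.5 percentage points higher from compound 2 to compound 3 (beyond the scatter), so the low value of compound 2 goes with this ethyl to methyl difference far more than with the nitro group. Nitro in place of hydrogen on an aromatic carbon gives only a modest step, a number 13.3 percentage points lower from compound 1 to compound 3 (beyond the scatter), which is beyond the scatter but leaves most of the inhibition in place. No measurement shown here accounts for why this small chain change matters so much.

Within the data shown here, the ethyl step is seen only with the nitro group present, so it remains open whether ethyl would cost as much without it. On these data alone, how a propyl chain on the same carbon, or an amine in place of the nitro group, would read also remains open.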